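The source may hold more compounds than are shown below. What is called first, only, known or untested is meant among the compounds shown, and "the series" means these compounds.

Compound 1 `CCOc1ncc(-c2nc(C(F)(F)F)sc2N2CCN(C(=O)Cn3nc(C)nc3C)[C@H](C)C2)cn1` gives 7 nM in a functional assay on CHO-K1 cells for antagonist activity at C-X-C chemokine receptor type 3 (Homo sapiens), read by FLIPR, with a stated time of 10 min; on this read-out lower numbers stand for stronger inhibition and higher numbers for weaker inhibition. Compound 2 `Cc1nc(C)n(CC(=O)N2CCN(c3sc(C(F)(F)F)nc3-c3cnc(C(C)(C)C)nc3)C[C@H]2C)n1` gives 8.7 nM in this assay; on the numbers shown it sits within the scatter of compound 1, the step of a 1.2-fold higher number from compound 1 to compound 2 (0.09 log units; within the scatter) being within the scatter. Compound 3 `Cc1nc(C)n(CC(=O)N2CCN(c3sc(C(F)(F)F)nc3-c3ccc(C(F)(F)F)nc3)C[C@H]2C)n1` carries 6-(trifluoromethyl)pyridin-3-yl in place of 2-(tert-butyl)pyrimidin-5-yl on an aromatic carbon. Going by the values given here, no measured step bears directly on this exchange; the only step known, a 1.2-fold higher number from compound 1 to compound 2 (0.09 log units; within the scatter), swaps a group on the same aromatic carbon and gives no direction. The step of a 1.4-fold higher number from compound 2 to compound 3 (0.14 log units; within the scatter) is therefore expected to be none beyond the scatter. Compound 3 is estimated at 12 nM, range 4 nM to 40 nM.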

Compound 3, half-maximal inhibitory concentration: 4.2 nM
For compound 3 the middle estimate is 2.9-fold (0.46 log units) above the measured one; measured number inside the range.
By their numbers in this assay, from the lowest: compounds 3, 1 and 2 (each within the scatter of the next, the first and the last beyond it).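

In this assay this aromatic carbon gives its first separation beyond the scatter, with 6-(trifluoromethyl)pyridin-3-yl in place of 2-(tert-butyl)pyrimidin-5-yl producing a 2.1-fold lower number from compound 2 to compound 3 (0.32 log units; beyond the scatter) and only a modest one. The same group in place of 2-ethoxypyrimidin-5-yl gives a 1.7-fold lower number from compound 1 to compound 3 (0.22 log units; within the scatter) and so holds no separation from that partner. Nothing available explains the difference.

The step changes the ring and its substituent together, leaving their separate contributions open. Also open, going by these compounds, is how an amine or a carboxylic acid on the pyridine ring would read here.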